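Shortening the propyl chain on the shared core

This account rests on a few compounds, and the source may have more. Where it says the series, first, only, none or still open, it means among the compounds named here.

Compound 3 `CCCc1nc2ccccc2c(=O)n1/N=C/c1ccc(Oc2ccc(Cl)c(C)c2)cc1` has the highest value of the three compounds measured in a physicochemical assay for lipophilicity, in phosphate buffer, measured as octanol-water partition (on this read-out lower numbers stand for lower lipophilicity and higher numbers for higher lipophilicity), at 6.02. Its nearest neighbour is compound 1 `CCCc1nc2ccccc2c(=O)n1/N=C/c1ccc(Oc2ccc(Cl)cc2)cc1`, which in this assay gives 5.78; the step of a number 0.24 log units higher from compound 1 to compound 3 (within the scatter) is within the scatter. Furthest away is compound 2 `Cc1ccc(Oc2ccc(/C=N/n3c(C)nc4ccccc4c3=O)cc2)cc1`, which gives 4.32 in this assay, a gap beyond the scatter. Compound 4 `Cc1cc(Oc2ccc(/C=N/n3c(C)nc4ccccc4c3=O)cc2)ccc1Cl` differs from compound 3 by hydrogen in place of ethyl on a saturated chain carbon bound to an aromatic carbon. Within the data shown here, no measured step covers this change directly: the only measured step, from compound 1 to compound 3, concerns a methyl on an aromatic carbon and was small. Compound 2 and compound 1 differ in two places, one of them this same propyl to methyl exchange, and their values differ by a wide margin. Compound 4 is therefore expected to sit clearly below compound 3, with an estimated step of a number 1.02 log units lower from compound 3 to compound 4 (beyond the scatter). For compound 4 the estimate in this assay is 5, within a range of 4.5 to 5.5.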

Compound 4, partition coefficient: 4.41
Compound 4: middle estimate off by 0.59 log units, on the high side, and the stated range ends above it.
By their numbers in this assay, from the lowest: compounds 2 and 4 (each within the scatter of the next); then compounds 1 and 3 (each within the scatter of the next).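

In this assay, the exchange of propyl for methyl on the shared core now stands as a single change, and it gives a number 1.61 log units lower from compound 3 to compound 4 (beyond the scatter), with the rest of the molecule held fixed. The change at the other end of the molecule, 4-chloro-3-methylphenyl in place of 4-methylphenyl on an oxygen on an aromatic ring, gives a number 0.09 log units higher from compound 2 to compound 4 (within the scatter), so among these pairs only the chain exchange moves the number beyond the scatter.

The compounds shown leave open what an ethyl chain would give at this place, and whether a longer chain such as butyl would carry the trend further. They also leave open whether an amine at the end of the chain would change the picture, and no measurement available here accounts for the size of this step.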